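From compound 3 to compound 4: bromomethyl to methoxy

This account rests on a few compounds, and the source may have more. Where it says the series, first, only, none or still open, it means among the compounds named here.

In an ADME assay on L929 cells (Mus musculus) for cytotoxicity, read by resazurin assay, with a stated time of 48 h (a lower number here means that less compound is tolerated, a higher number that more compound is tolerated), compound 1 `C#CCn1c2ccc([N+](=O)[O-])cc2c(=O)n1Cc1ccccc1` gives 195000 nM, compound 2 `CCOC(=O)CCCn1c2ccc([N+](=O)[O-])cc2c(=O)n1Cc1ccccc1` gives 78100 nM and compound 3 `O=[N+]([O-])c1ccc2nn(Cc3ccccc3)c(OCCCBr)c2c1` gives 59000 nM. Compound 3 lies within the scatter of compound 2 and beyond the scatter under compound 1.

Compound 4 `COCCOc1c2cc([N+](=O)[O-])ccc2nn1Cc1ccccc1` has not yet been measured. It differs from compound 3 in one place: methoxy in place of bromomethyl on a saturated chain carbon, two bonds along the chain from an oxygen on an aromatic ring. This is methoxy in place of bromomethyl on a saturated chain carbon, two bonds along the chain from an oxygen on an aromatic ring, so 3-bromopropoxy becomes 2-methoxyethoxy.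

Going by the values given here, the only measured step is a 2.5-fold lower number from compound 1 to compound 2 (0.40 log units; beyond the scatter). It is modest, but it involves other groups, on a saturated chain carbon bound to an aromatic nitrogen, so it gives only a rough guide to size. Among the compounds with values here, no measured step covers this change. Within the data shown here, a small move to a higher number in this assay is expected, probably within the scatter and no larger than that step. The lean is weak and rests on compound 1 at 195000 nM and compound 2 at 78100 nM, neither of which carries bromomethyl. The expected change is a 1.5-fold higher number from compound 3 to compound 4 (0.18 log units; within the scatter). Compound 4 is estimated at 90000 nM, with an expected range of 40000 nM to 200000 nM.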

Compound 4, concentration lethal to 50% of the cells: > 256000 nM
Compound 4 gave a limit, no number; the forecaster's own chance of this, stated with the estimate: 5%; middle value at least 2.8-fold (0.45 log units) away from the limit.
By their numbers in this assay, from the lowest: compounds 3 and 2 (each within the scatter of the next); then compound 1. At a limit, above all of these: compound 4.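

In this assay, replacing 3-bromopropoxy with 2-methoxyethoxy, with the rest of the molecule unchanged, gives an at least 4.3-fold higher number from compound 3 to compound 4 (0.63 log units; beyond the scatter). This is the only step shown on the chain on the oxygen, and it places a change at the chain end beyond the scatter, whereas the one earlier step, a 2.5-fold lower number from compound 1 to compound 2 (0.40 log units; beyond the scatter), concerns a different substituent on a saturated chain carbon bound to an aromatic nitrogen. Compound 4 gives > 256000 nM, a limit and not a number, so the step can be read only as a minimum: the limit of > 256000 nM in this assay, at which 1 of the 4 values shown sits.

On these data alone, the pair does not separate the loss of bromine from the gain of the ether oxygen, and how a plain propoxy chain, carrying neither, would read remains unknown. Also open, as far as these compounds go, is whether a terminal amine, a carboxylic acid or a longer chain ending in methoxy at this position would stay at the limit, and whether the same exchange would carry over to the chain on the aromatic nitrogen.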